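Hydroxyalkyl substitution on the sulfonyl-bearing ring: clearance notes

A few compounds are considered here, and "the series" means these few. Any claim that something is new, unique, unknown or untested is made for them only; others in the source may bear on it.

Compound 1 `CC(C)(O)c1cn(-c2ccc(-c3cccc(S(C)(=O)=O)c3)cc2)c(C(C)(C)c2ccccc2Cl)n1` is the reference point of this pair. Among the compounds with values here, in an ADME assay on the whole organism (Macaca fascicularis) for pharmacokinetics, read by LC-MS, using cassette dosing, at a dose of 0.2 mg/kg by the intravenous route (on this read-out higher numbers stand for fast clearance and lower numbers for slow clearance), compound 1 gives 2.9 mL/min/kg, the lowest of the two numbers so far. Compound 2 `CC(C)(O)c1cn(-c2ccc(-c3cc(F)c(CO)c(S(C)(=O)=O)c3)cc2)c(C(C)(C)c2ccccc2Cl)n1` carries extra fluorine and hydroxymethyl substituents on the same ring; in this assay compound 2 gives 8.4 mL/min/kg, a higher number than that of compound 1, and the gap between them lies beyond the usual scatter.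

Compound 3 `CC(O)c1ccc(-c2ccc(-n3cc(C(C)(C)O)nc3C(C)(C)c3ccccc3Cl)cc2)cc1S(C)(=O)=O` is not yet measured in this assay. It differs from compound 1 by 1-hydroxyethyl in place of hydrogen on an aromatic carbon, the entering group sitting ortho to a methylsulfonyl group and para to a large group on the six-membered aromatic ring of carbon only.

Because compound 2 gives 8.4 mL/min/kg where a hydroxymethyl group has been added to the same ring, a move toward higher clearance is expected for compound 3 as well, with the step from compound 1 to compound 3 estimated at a 1.9-fold higher number from compound 1 to compound 3 (0.28 log units; within the scatter). Compound 3 is therefore expected to give about 5.5 mL/min/kg, within a range from 2.5 mL/min/kg to 12 mL/min/kg.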

Compound 3, clearance: 5.6 mL/min/kg
For compound 3 the middle estimate is 1.0-fold (0.01 log units) below the measured one; the measured number falls inside the stated range.
By their numbers in this assay, from the lowest: compounds 1, 3 and 2 (each within the scatter of the next, the first and the last beyond it).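

Within the data shown here, compound 3 is the first change confined to one place: 1-hydroxyethyl in place of hydrogen on the aromatic carbon ortho to a methylsulfonyl group and para to a large group. In this assay the step of a 1.9-fold higher number from compound 1 to compound 3 (0.29 log units; within the scatter) stays within the usual scatter, so this single substitution on the core of compound 1 cannot be told apart from no change on this read-out, something compound 2, with fluorine and hydroxymethyl changed together, could not show. No measurement at hand speaks to the reason for this outcome.

Still open, on these data alone, is whether any group at this same aromatic carbon gives a step beyond the scatter, for instance an amine, a carboxylic acid or a longer hydroxyalkyl chain. The separate contributions of fluorine and hydroxymethyl in compound 2 also remain unresolved, since neither appears alone among the compounds shown.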